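The source may report more compounds than this note shows. Statements on the series, on what has been measured and on what is new or still open speak of the compounds shown alone.

Measured so far:
compound 1, `Cc1ccc(Nc2nc(C)c(C(=O)/C=C/c3ccccc3)s2)cc1` — > 25000 nM in a functional assay on BGC-823 cells (Homo sapiens) for cytotoxicity, read by MTT assay; a higher number here means a weaker inhibitor, a lower number a stronger inhibitor
compound 2, `Cc1nc(Nc2ccc(Cl)c(Cl)c2)sc1C(=O)/C=C/c1ccccc1` — 10600 nM in this assay

In this assay compound 1 gives > 25000 nM, which is a limit of the assay and not a number (the limit of > 25000 nM in this assay, at which 1 of the 2 values shown sits). Compound 2 gives 10600 nM. Among the measured compounds shown here, the single measured step, an at least 2.3-fold lower number from compound 1 to compound 2 (0.37 log units; beyond the scatter), replaces the 4-methylphenyl on the ring nitrogen with 3,4-dichlorophenyl; it says nothing about the other end of the molecule.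

Compound 3, `COc1cccc(/C=C/C(=O)c2sc(Nc3ccc(C)cc3)nc2C)c1`, keeps the 4-methylphenyl of compound 1 and differs from it only at the far ring: methoxy in place of hydrogen on an aromatic carbon. Cut one bond further out, the change reads phenyl to 3-methoxyphenyl, on the side of the carbonyl and the alkene.

For the measured compounds named here, no measured step bears on this position, so nothing indicates a shift beyond the scatter in either direction. Compound 1 sits at the limit, and compound 3 is expected to stay close to it. The step expected is a step that the limit leaves unreadable from compound 1 to compound 3. Compound 3 is estimated at 30000 nM, within a range from 10000 nM to 100000 nM, and a limit rather than a number is the likelier report.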

Compound 3, half-maximal inhibitory concentration: > 25000 nM
Compound 3 gave a limit, no number (the forecaster's own chance of this, stated with the estimate: 65%); the middle value is on the limit's open side.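

Compound 1 and compound 3 both sit at a limit of the assay and not at a number, so no step can be read for the methoxy change in this assay: the limit of > 25000 nM in this assay, at which 2 of the 3 values shown sit.

The compounds shown leave open whether 3-methoxyphenyl in place of phenyl changes the value in either direction.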